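Chloro to Methyl at the Weak End of the Range

This account rests on a few compounds, and the source may have more. Where it says the series, first, only, none or still open, it means among the compounds named here.

Within the data shown here, in a functional assay on A549 cells (Homo sapiens) for antiproliferative activity, read by spectrophotometry, with a stated time of 2 days (on this read-out higher numbers stand for weaker inhibition of growth and lower numbers for stronger inhibition of growth), compound 2 (`Cc1cc(Cl)ccc1Nc1ncc(C(F)(F)F)c(N2Cc3cccc(N(C)S(C)(=O)=O)c3C2)n1`) gives 25500 nM as the only true number so far. In this assay compound 1 (`Cc1cc(C)cc(Nc2ncc(C(F)(F)F)c(N3Cc4cccc(N(C)S(C)(=O)=O)c4C3)n2)c1`) shows > 30000 nM as a limit of the assay and not a number. Among the measured compounds shown here, the one measured step reads an at least 1.1-fold lower number from compound 1 to compound 2 (0.07 log units; that floor lies within the scatter) when 4-chloro-2-methylphenyl replaces 3,5-dimethylphenyl, and it rests on the limit of > 30000 nM in this assay, at which 1 of the 2 values shown sits, so it offers only a floor. Compound 3 (`Cc1ccc(Nc2ncc(C(F)(F)F)c(N3Cc4cccc(N(C)S(C)(=O)=O)c4C3)n2)c(C)c1`) carries methyl in place of chloro on an aromatic carbon, para to a large group, a swap counted as methyl in place of chloro on an aromatic carbon in full. For the measured compounds named here, no measured step isolates this swap, and the only nearby step stays within the scatter, so no shift beyond the scatter is expected in this assay and no firm direction either. The expected change is a 1.1-fold higher number from compound 2 to compound 3 (0.04 log units; within the scatter) and thus lies within the scatter. Compound 3 is estimated at 28000 nM with a range of 14000 nM to 50000 nM and may well report only a limit.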

Compound 3, concentration for 50% growth inhibition: 20700 nM
For compound 3 the middle estimate is 1.4-fold (0.13 log units) above the measured one; the measured number falls inside the stated range.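

With compound 3 the swap of chloro for methyl, on an aromatic carbon para to a large group, can be read alone in this assay, and it gives a 1.2-fold lower number from compound 2 to compound 3 (0.09 log units; within the scatter). At this position the two groups cannot be told apart on this read-out. The step with 2,4-dimethylphenyl in place of 3,5-dimethylphenyl gives only a floor, an at least 1.4-fold lower number from compound 1 to compound 3 (0.16 log units; that floor lies within the scatter), and that floor rests on compound 1, whose entry is a limit of the assay and not a number: the limit of > 30000 nM in this assay, at which 1 of the 3 values shown sits.

The compounds shown leave open whether any group at this position moves the number beyond the scatter, since only chloro and methyl appear there, and a methoxy group, a nitrile or an amine would put that to the test. They also leave open how far the shared core, rather than the substituted phenyl on its nitrogen, sets the level of growth inhibition.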